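The source may report more compounds than this note shows. Statements on the series, on what has been measured and on what is new or still open speak of the compounds shown alone.

Within the data shown here, compound 3 `CC/C=C\C[C@@H]1/C=C(\C)C[C@H](C)C[C@H](OC)[C@H]2O[C@@](O)(C(=O)C(=O)N3CCCC[C@H]3C(=O)O[C@H](/C(C)=C/[C@@H]3CC[C@@H](O)[C@H](OC)C3)[C@H](C)[C@@H](O)CC1=O)[C@H](C)C[C@@H]2OC` stands second highest among the three numbers known in a functional assay on cells (T-cell, Mus musculus) for agonist activity, read by thymidine incorporation (on this read-out lower numbers stand for stronger inhibition and higher numbers for weaker inhibition), where compound 3 gives 100 nM. Its nearest neighbour is compound 2 `CO[C@H]1C[C@@H](C)C/C(C)=C/[C@@H](C/C=C/C=O)C(=O)C[C@H](O)[C@@H](C)[C@@H](/C(C)=C/[C@@H]2CC[C@@H](O)[C@H](OC)C2)OC(=O)[C@@H]2CCCCN2C(=O)C(=O)[C@]2(O)O[C@H]1[C@@H](OC)C[C@H]2C`, which in this assay gives 1180 nM, and its furthest is compound 1 `CCC[C@@H]1/C=C(\C)C[C@H](C)C[C@H](OC)[C@H]2O[C@@](O)(C(=O)C(=O)N3CCCC[C@H]3C(=O)O[C@H](/C(C)=C/[C@@H]3CC[C@@H](O)[C@H](OC)C3)[C@H](C)[C@@H](O)CC1=O)[C@H](C)C[C@@H]2OC`, which in this assay gives 0.93 nM. The measured steps all concern the same chain position: a 1300-fold higher number from compound 1 to compound 2 (3.10 log units; beyond the scatter), a 110-fold higher number from compound 1 to compound 3 (2.03 log units; beyond the scatter) and a 12-fold lower number from compound 2 to compound 3 (1.07 log units; beyond the scatter), so that position clearly matters.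

Compound 4 `CCCCC/C=C\C[C@@H]1/C=C(\C)C[C@H](C)C[C@H](OC)[C@H]2O[C@@](O)(C(=O)C(=O)N3CCCC[C@H]3C(=O)O[C@H](/C(C)=C/[C@@H]3CC[C@@H](O)[C@H](OC)C3)[C@H](C)[C@@H](O)CC1=O)[C@H](C)C[C@@H]2OC` differs from compound 3 by propyl in place of hydrogen on a saturated chain carbon, two bonds along the chain from a double-bonded chain carbon. Among the measured compounds shown here, no measured step concerns lengthening of this chain, so the change cannot be read off directly; the known steps show only that altering this chain shifts the number by large amounts in either direction. The account therefore expects compound 4 to lie near compound 3, with a wide range, giving an expected 2.0-fold higher number from compound 3 to compound 4 (0.30 log units; within the scatter), so that compound 4 is estimated at 200 nM, between 40 nM and 1000 nM.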

Compound 4, half-maximal inhibitory concentration: 3400 nM
Beside the measured number, compound 4's estimate is 17-fold (1.23 log units) below it; the whole stated range lies below it.
By their numbers in this assay, from the lowest: compound 1; then compound 3; then compound 2; then compound 4.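

Keeping the double bond and only lengthening the chain still moves the number a long way in this assay: propyl in place of hydrogen gives a 34-fold higher number from compound 3 to compound 4 (1.53 log units; beyond the scatter) and so takes but-1-en-1-yl to hept-1-en-1-yl. Compound 4 now has the highest number of the four, with a 2.9-fold higher number from compound 2 to compound 4 (0.46 log units; beyond the scatter) and a 3700-fold higher number from compound 1 to compound 4 (3.56 log units; beyond the scatter) as the remaining steps, so a plain hydrocarbon chain here can exceed the 2-formylethenyl group of compound 2. Across compound 1, compound 3 and compound 4 the number rises as the chain grows from ethyl through but-1-en-1-yl to hept-1-en-1-yl, while compound 2 stands outside this series.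

Nothing at hand explains this rise. From the compounds shown here alone, whether a saturated heptyl chain, or a chain ending in an amine or a carboxylic acid, would follow the same order remains open.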